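Swapping a Dimethylamino for a Pyrrolidine Ring

The compounds below may be only part of what the source reports. "The series", "measured", "known", "first", "only" and "open" are said of these compounds alone.

Three compounds share a core that carries a dithiocarbamate-type side chain, and all have been tested in a functional assay on MCF7 cells (Homo sapiens) for antiproliferative activity, read by MTT assay, with a stated time of 72 h; a lower number here means a stronger inhibitor, a higher number a weaker inhibitor. Compound 1 `O=C1OCC=C1CSC(=S)NC1CC1` gives 94900 nM. Compound 3 `O=C1OCC=C1CSC(=S)Nc1ccccc1` gives 89900 nM. Compound 2 `CN(C)C(=S)SCC1=CC(=O)OC1` gives 159000 nM. Its number is the largest of the three, yet the gaps to compound 1 and to compound 3 both lie within the usual scatter of repeated measurements, so the three compounds stand level in this assay and none can be called weaker or stronger than the others.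

Compound 4 `O=C1C=C(CSC(=S)N2CCCC2)CO1` has not yet been measured. It differs from compound 2 in one place: pyrrolidin-1-yl in place of dimethylamino on a thiocarbonyl carbon. The two nitrogen substituents of the dimethylamino group are thus tied together into a ring. Within the data shown here, no measured pair in this set shows the effect of such a change, so there is nothing to anchor a direction. The expectation for the step from compound 2 to compound 4 is therefore a 1.2-fold lower number from compound 2 to compound 4 (0.09 log units; within the scatter), a change not beyond the scatter. Compound 4 is estimated at 130000 nM, with a range from 60000 nM to 300000 nM.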

Compound 4, half-maximal inhibitory concentration: 169000 nM
Beside the measured number, compound 4's estimate is 1.3-fold (0.11 log units) below it; the measured number falls inside the stated range.
By their numbers in this assay, from the lowest: compounds 3, 1, 2 and 4 (each within the scatter of the next).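

Closing the dimethylamino group into a pyrrolidin-1-yl ring on the thiocarbonyl carbon gives a 1.1-fold higher number from compound 2 to compound 4 (0.03 log units; within the scatter) in this assay and so provides the first measured step at this position. Compound 2 and compound 4 stand level, which shows that this position accepts a ring in place of the open dimethylamino group with no readable change in the number, at least for this one five-membered ring. No supporting measurement on these compounds offers an explanation for this flat step.

Still open, on these data alone, is whether a piperidine or morpholine ring on the same thiocarbonyl carbon would also stay level with compound 2. A hydroxyl group or a carboxylic acid attached to the pyrrolidine ring is also untested in the compounds shown here, so its effect on the number remains unknown.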